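This account rests on a few compounds, and the source may have more. Where it says the series, first, only, none or still open, it means among the compounds named here.

Of the compounds shown here, two have so far been measured in a functional assay on Hs-578T cells (Homo sapiens) for inhibition, read by sulforhodamine B assay, with a stated time of 48 h; on this read-out higher numbers stand for weaker inhibition of growth and lower numbers for stronger inhibition of growth. Compound 1, `COc1cc(C(=O)N2CCN(C=O)C2=S)cc(OC)c1OC`, gives in this assay 27600 nM. Compound 2, `O=CN1CCN(c2ccc(Cl)cc2)C1=S`, gives in this assay 49600 nM. The two numbers lie within the scatter of each other, so neither compound can be set apart from the other on this read-out, and nothing in these two values amounts to a step; compound 2 simply stands at the same level as compound 1. Compound 3, `O=CN1CCN(c2ccc(Cl)c(Cl)c2)C1=S`, differs from compound 2 in one place: chloro in place of hydrogen on an aromatic carbon. Among the compounds with values here, no measured pair shows a change of this kind, so there is no step to lean on. The expectation for compound 3 in this assay is therefore a step of a 1.4-fold lower number from compound 2 to compound 3 (0.15 log units; within the scatter), that is, none beyond the scatter, with the number staying close to that of compound 2. Compound 3 is thus expected at 35000 nM, with a range from 12000 nM to 100000 nM.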

Compound 3, concentration for 50% growth inhibition: 39600 nM
Estimate against measurement, compound 3: 1.1-fold (0.05 log units) below; the range from low to high includes it.
By their numbers in this assay, from the lowest: compounds 1, 3 and 2 (each within the scatter of the next).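

In this assay chloro in place of hydrogen on an aromatic carbon, ortho to a chloro group and meta to a group of 8 heavy atoms, brings a 1.3-fold lower number from compound 2 to compound 3 (0.10 log units; within the scatter) and this lies within the scatter. Within the data shown here, as the only measured change at this position, it shows that adding this second chloro leaves growth inhibition at the same level on this read-out. No information is available on why the change has so little effect. Among these compounds, the single pair leaves open how this position would respond to a different group, such as a methoxy group, an amine or a carboxylic acid. It also leaves open whether chloro at this carbon, without the chloro group already on the ring, would give the same result.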